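From 4-Methoxyphenyl to 4-Hydroxyphenyl in Compound 3

This account rests on a few compounds, and the source may have more. Where it says the series, first, only, none or still open, it means among the compounds named here.

Compound 1, `CC1=CC[C@@H]([C@@](C)(O)CCCC(C)(C)NC(=S)NN)CC1`, gives 84000 nM in a functional assay on NCI-H460 cells (Homo sapiens) for cytotoxicity, read by sulforhodamine B assay; on this read-out lower numbers stand for stronger inhibition of growth and higher numbers for weaker inhibition of growth.
Compound 2, `COc1ccc(/C=N\NC(=S)NC(C)(C)CCC[C@](C)(O)[C@@H]2CC=C(C)CC2)cc1`, reaches only the limit of > 100000 nM in this assay.

Compound 2 thus stands at the limit of this assay (the limit of > 100000 nM in this assay, at which 1 of the 2 values shown sits), so for it only a limit and no number is known. Among the measured compounds shown here, the single step measured so far runs from compound 1 to compound 2: an at least 1.1-fold higher number from compound 1 to compound 2 (0.07 log units; that floor lies within the scatter). Compound 3, `CC1=CC[C@@H]([C@@](C)(O)CCCC(C)(C)NC(=S)N/N=C\c2ccc(O)cc2)CC1`, differs from compound 2 by hydrogen in place of methyl on an oxygen on an aromatic ring. For the measured compounds named here, no measured step bears on this change; the step from compound 1 to compound 2 concerns another site and says nothing about it. With compound 2 known only as a limit, any estimate for compound 3 in this assay can rest only on that limit and on the small size of the change. The change from compound 2 to compound 3 is expected to give a number no higher from compound 2 to compound 3 (the limit leaves the size open), that is, no step beyond the scatter. Compound 3 is therefore estimated at about 100000 nM in this assay, between 40000 nM and 250000 nM, and may again be reported only as a limit.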

Compound 3, concentration for total growth inhibition: 20700 nM
The estimate for compound 3 lay 4.8-fold (0.68 log units) above the measured number; the whole stated range lies above it.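

In this assay, among the compounds shown here, the change at this position turns out to matter, which the earlier compounds could not show: replacing the methyl on the oxygen on the aromatic ring with hydrogen gives an at least 4.8-fold lower number from compound 2 to compound 3 (0.68 log units; beyond the scatter). For the compounds shown here, the aromatic group as such does not settle the outcome, since the only earlier step that added one, with its methoxy group, gave an at least 1.1-fold higher number from compound 1 to compound 2 (0.07 log units; that floor lies within the scatter), whereas the group carrying hydroxy gives a 4.1-fold lower number from compound 1 to compound 3 (0.61 log units; beyond the scatter), so that the 4-hydroxyphenyl compound is the one that improves on the unsubstituted core of compound 1. Compound 2 is known only as a limit, so the step that removes the methyl gives a floor and not a full size: the limit of > 100000 nM in this assay, at which 1 of the 3 values shown sits.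

The compounds shown leave open whether the gain is specific to hydroxy or would also appear with an amine or a carboxylic acid in the same place on the aromatic ring. They also leave open whether a longer chain on that oxygen, such as ethoxy, would behave like methoxy, and whether the step seen here holds on any cells other than those of this single read-out.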